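A few compounds are considered here, and "the series" means these few. Any claim that something is new, unique, unknown or untested is made for them only; others in the source may bear on it.

Working notes on the series. Compound 3 `CCOC(C)(COC1CCN(c2nc(N)c3cc(OC)c(OC)cc3n2)CC1)c1ccccc1` gives 0.15 nM in an assay on brain for displacement of a labelled ligand from Adrenergic receptor alpha-1 (Rattus norvegicus) (a lower number here means a stronger inhibitor, a higher number a weaker inhibitor), the lowest of the three numbers: compound 1 `CCCCOCCOC1CCN(c2nc(N)c3cc(OC)c(OC)cc3n2)CC1` gives 1.03 nM and compound 2 `COc1cc2nc(N3CCC(OCC(C)(C)O)CC3)nc(N)c2cc1OC` gives 1.28 nM, and the two steps toward compound 3 were a 6.9-fold lower number from compound 1 to compound 3 (0.84 log units; beyond the scatter) and an 8.5-fold lower number from compound 2 to compound 3 (0.93 log units; beyond the scatter). The move from compound 1 to compound 2 was a 1.2-fold higher number from compound 1 to compound 2 (0.09 log units; within the scatter). Compound 4 `COc1cc2nc(N3CCC(OCC(O)c4ccccc4)CC3)nc(N)c2cc1OC` is not yet measured; it differs from compound 3 by hydroxy(phenyl)methyl in place of 1-ethoxy-1-phenylethyl on a saturated chain carbon bound to an oxygen on a saturated carbon. The phenyl ring is kept, but the ethoxy and methyl groups go and a hydroxy comes in, so the change partly reverses what compound 2 and compound 3 show: compound 2, which carries a hydroxy on the chain, sits well above compound 3, and the step of an 8.5-fold lower number from compound 2 to compound 3 (0.93 log units; beyond the scatter) is the one that bears most directly. A number between those of compound 3 and compound 2 is therefore expected, with the step of a 3.3-fold higher number from compound 3 to compound 4 (0.52 log units; beyond the scatter) estimated to run upward but not to return to the level of compound 2. For compound 4 the estimate in this assay is 0.5 nM, with a range from 0.18 nM to 1.5 nM.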

Compound 4, inhibition constant: 0.15 nM
Beside the measured number, compound 4's estimate is 3.3-fold (0.52 log units) above it; measured number outside the range, below it.
By their numbers in this assay, from the lowest: compounds 3 and 4 (each within the scatter of the next); then compounds 1 and 2 (each within the scatter of the next).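

In this assay, no change at the digits printed from compound 3 to compound 4 (within the scatter): with the phenyl ring kept, hydroxy(phenyl)methyl can stand in place of 1-ethoxy-1-phenylethyl at this position, so the ethoxy and methyl groups are not needed for a number at this level. The hydroxy does not set compound 2 apart, since compound 4 carries one too, yet there is an 8.5-fold lower number from compound 2 to compound 4 (0.93 log units; beyond the scatter) and also a 6.9-fold lower number from compound 1 to compound 4 (0.84 log units; beyond the scatter); among these four compounds, both that carry a phenyl ring have lower numbers than both that lack one, and none goes against this. Nothing shown gives a reason for these steps.

Open, from the compounds shown here alone, is whether an amine or a carboxylic acid can take the place of the hydroxy with the phenyl ring kept. Also open, going by these compounds, is whether a longer chain carrying the phenyl ring stays at this level.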